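Moving the Fluorine on the Benzyl Amide

This account rests on a few compounds, and the source may have more. Where it says the series, first, only, none or still open, it means among the compounds named here.

Measured compounds:
compound 1 `CN(Cc1cccc(F)c1)C(=O)CCCNC(=O)c1ccc(S(C)(=O)=O)c([N+](=O)[O-])c1`: > 60000 nM
compound 2 `CS(=O)(=O)c1ccc(C(=O)NCCCC(=O)N2CCCCC2)cc1[N+](=O)[O-]`: > 60000 nM

Compound 1 and compound 2 were both tested in an assay on isolated protein for inhibition of vitamin D3 receptor (Homo sapiens), read by fluorescence polarization; on this read-out lower numbers stand for stronger inhibition and higher numbers for weaker inhibition. In this assay compound 1 gives > 60000 nM, which is a limit of the assay rather than a number. Compound 2 gives > 60000 nM, also a limit. The step that the two limits leave unreadable from compound 1 to compound 2 therefore cannot be read, because both values sit at the limit of > 60000 nM in this assay, at which 2 of the 2 values shown sit. Compound 2 thus stands at the limit, and nothing more can be said of its place among the numbers shown.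

Compound 3 `CN(Cc1ccccc1F)C(=O)CCCNC(=O)c1ccc(S(C)(=O)=O)c([N+](=O)[O-])c1` differs from compound 2 in one place: (2-fluorobenzyl)(methyl)amino in place of piperidin-1-yl on a carbonyl carbon. For the measured compounds named here, the only measured step that bears on this position, from compound 1 to compound 2, is unreadable in size, so no direction can be drawn from it. The step from compound 2 to compound 3 is therefore expected to be a step that the limit leaves unreadable from compound 2 to compound 3, most likely ending again at a limit. Compound 3 is estimated at 100000 nM, within a range from 40000 nM to 300000 nM.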

Compound 3, half-maximal inhibitory concentration: > 60000 nM
Compound 3: no number, only a limit (the forecaster's own chance of this, stated with the estimate: 85%); the middle value is on the limit's open side.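

In this assay compound 3 gives > 60000 nM, a limit of the assay and not a number, so its steps to compound 1 and compound 2 cannot be read, because: the limit of > 60000 nM in this assay, at which 3 of the 3 values shown sit.

The compounds shown leave open whether either change alters inhibition at all, since none of the three has a number.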